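Replacing an aromatic ring with cyclohexyl on a long-chain amide

The compounds below may be only part of what the source reports. "The series", "measured", "known", "first", "only" and "open" are said of these compounds alone.

Compound 1 `O=C(/C=C\CCCCCCc1ccccc1)N1CCCCC1`: in a functional assay on PANC-1 cells (Homo sapiens) for cytotoxicity, read by WST assay, with a stated time of 24 h (on this read-out higher numbers stand for weaker inhibition and lower numbers for stronger inhibition), compound 1 gives > 100000 nM, a limit of the assay.
Compound 2 `Cc1ccc(CCCCCCCCC(=O)N2CCCCC2)cc1`: in this assay compound 2 gives > 100000 nM, likewise a limit.

Compound 2 therefore stands at the limit rather than at a number, a position shared by both values shown (the limit of > 100000 nM in this assay, at which 2 of the 2 values shown sit). Compound 3 `O=C(CCCCCCCCC1CCCCC1)N1CCCCC1` differs from compound 2 by cyclohexyl in place of 4-methylphenyl on a saturated chain carbon, eight bonds along the chain from a carbonyl carbon. Among the measured compounds shown here, no step between measured compounds is known, so in this assay the step of a number no higher from compound 2 to compound 3 (the limit leaves the size open) is expected to be none beyond the scatter. Compound 3 is thus estimated at 100000 nM, within 30000 nM to 300000 nM, most likely reported again only as a limit.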

Compound 3, half-maximal inhibitory concentration: > 100000 nM
Compound 3 was reported as a limit (the forecaster's own chance of this, stated with the estimate: 85%); the middle value sits exactly at the limit.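

Compound 2 and compound 3 both stop at a limit rather than a number, so no step between them can be read: the limit of > 100000 nM in this assay, at which 3 of the 3 values shown sit.

Whether cyclohexyl in place of 4-methylphenyl changes activity at all stays open in the compounds shown.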